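Enlarging the amide acyl group in an aminophenyl ketone series

This account rests on a few compounds, and the source may have more. Where it says the series, first, only, none or still open, it means among the compounds named here.

Measured compounds:
compound 1 `COc1ccc(N)c(C(=O)CCNC(C)=O)c1`: 30.7%
compound 2 `CCCC(=O)NCCC(=O)c1cc(OC)ccc1N`: 7.35%

Among the two compounds measured in an assay for inhibition of Nitric oxide synthase, inducible (Homo sapiens), read by scintillation counting, with a stated time of 30 min, tested at 1 mM (a lower number here means less inhibition, a higher number more inhibition at the concentration tested (going by the name of the read-out)), compound 1 gives 30.7%, the higher of the two numbers; compound 2 gives 7.35%, and the step of a number 23.4 percentage points lower from compound 1 to compound 2 (beyond the scatter) lies beyond the scatter. That step is the only one known, and it came from ethyl in place of hydrogen on a saturated chain carbon bound to a carbonyl carbon, an enlargement of the acyl group on the amide nitrogen.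

Compound 3 `COc1ccc(N)c(C(=O)CCNC(=O)C2CCCCC2)c1` differs from compound 1 by cyclohexyl in place of methyl on a carbonyl carbon, again an enlargement of that same acyl group, on the carbonyl carbon whose other neighbour is the amide-type nitrogen. Going by the step of a number 23.4 percentage points lower from compound 1 to compound 2 (beyond the scatter), a drop of similar size is expected for compound 3 in this assay, although only one step supports this. Compound 3 is therefore estimated at 9%, in the range 0% to 25%, which is expected to mean a step of a number 21.7 percentage points lower from compound 1 to compound 3 (beyond the scatter).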

Compound 3, a percentage reported as inhibition, at one concentration (the size of the read-out at that concentration, not a potency): 9.24%
For compound 3 the middle estimate is 0.2 percentage points below the measured one; low and high end bracket the measured number.
By their numbers in this assay, from the lowest: compounds 2 and 3 (each within the scatter of the next); then compound 1.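

In this assay, a second enlargement of the acyl group now stands beside the first: cyclohexyl in place of methyl on a carbonyl carbon gives a number 21.5 percentage points lower from compound 1 to compound 3 (beyond the scatter), so the loss seen with propyl is not confined to that one group. Cyclohexyl in place of propyl gives a number 1.9 percentage points higher from compound 2 to compound 3 (within the scatter), so at this place a six-membered ring and an open chain cannot be told apart in this assay, and only compound 1, with its methyl, stands apart from the other two. Nothing measured here offers an explanation for the loss.

On these data alone, it remains open whether ethyl, which lies between methyl and propyl, would keep part of the number of compound 1. As far as these compounds go, it is also open whether phenyl or an aminomethyl group on this carbonyl carbon would behave like propyl and cyclohexyl.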